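The source may hold more compounds than are shown below. What is called first, only, known or untested is meant among the compounds shown, and "the series" means these compounds.

In a functional assay on HCT-116 cells (Homo sapiens), read by MTT assay, with a stated time of 72 h (on this read-out higher numbers stand for weaker inhibition and lower numbers for stronger inhibition), the three measured compounds stand as follows.

Compound 1 `Nc1nc2c(c(-c3ccccc3)cn2[C@@H]2O[C@H](CO)[C@@H](O)[C@H]2O)c(=O)[nH]1` gives > 20000 nM, a limit of the assay.
Compound 2 `COc1ncnc2c1c(-c1ccccc1)cn2[C@@H]1O[C@H](CO)[C@@H](O)[C@H]1O` gives > 20000 nM, a limit of the assay.
Compound 3 `CNc1ncnc2c1c(-c1ccccc1)cn2[C@@H]1O[C@H](CO)[C@@H](O)[C@H]1O` gives > 100000 nM, a limit of the assay.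

Compound 3 thus stands at the limit of > 100000 nM in this assay, at which 1 of the 3 values shown sits, while the two other values sit at the limit of > 20000 nM in this assay, at which 2 of the 3 values shown sit; none of the three is a number. Among the compounds with values here, the only step between compounds that differ in one place, a step that the two limits leave unreadable from compound 2 to compound 3, cannot be read, because the limit of > 100000 nM in this assay, at which 1 of the 3 values shown sits, and the limit of > 20000 nM in this assay, at which 2 of the 3 values shown sit, bound both of its ends.

Compound 4 `CNc1ncnc2c1c(-c1cc3ccccc3o1)cn2[C@@H]1O[C@H](CO)[C@@H](O)[C@H]1O` differs from compound 3 in one place: 1-benzofuran-2-yl in place of phenyl on an aromatic carbon. Within the data shown here, no measured step bears on this change; the single measured step concerns methylamino in place of methoxy on an aromatic carbon, and it is itself unreadable. The numbers shown therefore give no size and no direction for the step in this assay, and the most that can be said is that all three measured compounds remained at a limit.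

On that basis compound 4 is estimated at 60000 nM, with a range from 10000 nM to 200000 nM. This estimate corresponds to an expected step of an at least 1.6-fold lower number from compound 3 to compound 4 (0.22 log units; that floor lies within the scatter), and a limit rather than a number is the likelier outcome.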

Compound 4, half-maximal inhibitory concentration: > 20000 nM
Compound 4: no number, only a limit; the forecaster's own chance of this, stated with the estimate: 70%; the middle value lies beyond the limit too.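

In this assay compound 4 gives > 20000 nM, which is a limit of the assay and not a number. Compound 3 also stands at a limit, so the step from compound 3 to compound 4 cannot be read. The compounds shown leave open whether 1-benzofuran-2-yl in place of phenyl changes the read-out at all, and in which direction.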